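Compound 4 and the chloro step from compound 3

This account rests on a few compounds, and the source may have more. Where it says the series, first, only, none or still open, it means among the compounds named here.

The three measured compounds share one core, seen in compound 1 `COc1cc2cc(Oc3ccc(NC(=O)Nc4ccccc4)cc3)c(C)nc2cc1OC`, which in a functional assay on SK-MEL-28 cells (Homo sapiens) for inhibition, read by sulforhodamine B assay, with a stated time of 48 h, tested at 10 uM (on this read-out higher numbers stand for a weaker effect at the one concentration tested and lower numbers for a stronger effect), gives 96.2%. Compound 2 `COc1cc2cc(Oc3ccc(NC(=O)Nc4ccc(C(F)(F)F)cc4)cc3)c(C)nc2cc1OC` gives 58.4% in this assay, and compound 3 `COc1cc2cc(Oc3ccc(NC(=O)Nc4cccc(C(F)(F)F)c4)cc3)c(C)nc2cc1OC` gives 26.7%. Compound 3 thus stands lowest of the three: a number 69.5 percentage points lower from compound 1 to compound 3 (beyond the scatter) and a number 31.7 percentage points lower from compound 2 to compound 3 (beyond the scatter) are both beyond the scatter, and a number 37.8 percentage points lower from compound 1 to compound 2 (beyond the scatter) is likewise large.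

Compound 4 `COc1cc2cc(Oc3ccc(NC(=O)Nc4ccc(Cl)c(C(F)(F)F)c4)cc3)c(C)nc2cc1OC` differs from compound 3 by chloro in place of hydrogen on an aromatic carbon. Among the measured compounds shown here, no measured step introduces a chloro, so none bears directly on this change; the steps so far concern only the trifluoromethyl group and its place on the ring, and all were large. The expectation for compound 4 therefore rests on compound 3 alone, whose value in this assay already leaves little room downward. Compound 4 is expected to show a number 6.7 percentage points lower from compound 3 to compound 4 (within the scatter), a step within the scatter or only a little beyond it. Compound 4 is accordingly estimated at 20% in this assay, with a range from 5% to 45%.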

Compound 4, a percentage reported as activity, at one concentration (the size of the read-out at that concentration, not a potency): -35.9%
Estimate against measurement, compound 4: 55.9 percentage points above; measured number below the stated range.
By their numbers in this assay, from the lowest: compound 4; then compound 3; then compound 2; then compound 1.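

Chloro in place of hydrogen, ortho to a trifluoromethyl group and para to a large group, is the first change in the series beyond the trifluoromethyl group and its place, and it gives a number 62.6 percentage points lower from compound 3 to compound 4 (beyond the scatter) in this assay at the single concentration tested. The value of compound 3 was therefore no floor, since compound 4 gives -35.9% and is the only one of the four on the negative side of zero, with a number 94.3 percentage points lower from compound 2 to compound 4 (beyond the scatter) and a number 132.1 percentage points lower from compound 1 to compound 4 (beyond the scatter) also large and beyond the scatter. Nothing available explains why this one chloro group has so large an effect.

Still open, from the compounds shown here alone, is whether fluoro, bromo, methyl or methoxy at this place would give a comparable step. Also open, going by these compounds, is whether the chloro group would do so on the phenyl ring without the trifluoromethyl group.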